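Changing the Aryl Group on the Ring Nitrogen Once More

The source may report more compounds than this note shows. Statements on the series, on what has been measured and on what is new or still open speak of the compounds shown alone.

Measured compounds:
Compound 1, `COc1ccc(/C=C\C(=O)O)c(OCc2cn(-c3ccc(NC(C)=O)cc3)nn2)c1CC=C(C)C`: 23400 nM
Compound 2, `COc1cccc(-n2cc(COc3c(/C=C\C(=O)O)ccc(OC)c3CC=C(C)C)nn2)c1`: 23200 nM

In a functional assay on A-431 cells (Homo sapiens) for cytotoxicity, read by MTT assay, with a stated time of 24 h (a lower number here means a stronger inhibitor, a higher number a weaker inhibitor), compound 1 gives 23400 nM, and in this assay compound 2 gives 23200 nM. Among the measured compounds shown here, the only step between them is a 1.0-fold lower number from compound 1 to compound 2 (0.00 log units; within the scatter). In this step 3-methoxyphenyl stands instead of 4-acetamidophenyl on the aromatic nitrogen. Compound 2 thus holds the lower of the two numbers, yet it and compound 1 sit at the same level once the scatter is taken into account.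

Compound 3, `COc1ccc(/C=C\C(=O)O)c(OCc2cn(-c3ccc(C#N)cc3)nn2)c1CC=C(C)C`, differs from compound 2 by 4-cyanophenyl in place of 3-methoxyphenyl on an aromatic nitrogen. The aryl group on the ring nitrogen is once again exchanged while the shared core stays the same. For the measured compounds named here, the single measured step that bears on this kind of exchange is a 1.0-fold lower number from compound 1 to compound 2 (0.00 log units; within the scatter), which did not move beyond the scatter. On that basis no step beyond the scatter is expected for compound 3 in this assay, that is a 1.0-fold lower number from compound 2 to compound 3 (0.00 log units; within the scatter). Compound 3 is therefore estimated at 23000 nM, with a range from 9000 nM to 60000 nM.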

Compound 3, half-maximal inhibitory concentration: 23000 nM
For compound 3 middle estimate and measured number coincide at the digits printed, and the stated range covers the measured number.
By their numbers in this assay, from the lowest: compounds 3, 2 and 1 (each within the scatter of the next).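

In this assay, the step of a 1.0-fold lower number from compound 2 to compound 3 (0.00 log units; within the scatter) shows that 4-cyanophenyl on the aromatic nitrogen gives the same reading as 3-methoxyphenyl, so a third aryl group, this one carrying a triple bond, joins the same level. The step of a 1.0-fold lower number from compound 1 to compound 3 (0.01 log units; within the scatter) is the more direct comparison, as the substituent on the aromatic carbon is the only difference: cyano stands in place of acetamido, and this exchange also stays within the scatter. Among these three compounds, no exchange at this position goes beyond the scatter, but no measurement is available that could explain this flat result.

As far as these compounds go, all three groups on the ring nitrogen are substituted phenyl rings, so it remains open whether an amine or a hydroxyl on that phenyl ring, or a simple butyl chain in place of the whole aryl group, would give a different number. Every compound shown also keeps the shared core unchanged, which leaves open how much a change there would alter the reading, and whether this position would matter more once the core is different.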